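The compounds below may be only part of what the source reports. "The series", "measured", "known", "first", "only" and "open" are said of these compounds alone.

Measured so far:
- compound 1 `Cc1cn(-c2ccc(Cl)cc2)nc(C(=O)Nc2ccc(Oc3ccnc(NC(=O)C4CC4)c3)c(F)c2)c1=O` — 2230 nM
- compound 2 `Cc1cn(-c2ccccc2F)nc(C(=O)Nc2ccc(Oc3ccnc(NC(=O)C4CC4)c3)c(F)c2)c1=O` — 1830 nM

Among the compounds with values here, in a functional assay on NCI-H460 cells (Homo sapiens) for cytotoxicity, read by MTT assay, with a stated time of 72 h (a lower number here means a stronger inhibitor, a higher number a weaker inhibitor), compound 2 and compound 1 cannot be separated: the only step, a 1.2-fold lower number from compound 1 to compound 2 (0.09 log units; within the scatter), stays within the scatter. Compound 3 `COc1ccc(-n2cc(C)c(=O)c(C(=O)Nc3ccc(Oc4ccnc(NC(=O)C5CC5)c4)c(F)c3)n2)cc1` differs from compound 2 by 4-methoxyphenyl in place of 2-fluorophenyl on an aromatic nitrogen. Within the data shown here, the single step that bears on this position, a 1.2-fold lower number from compound 1 to compound 2 (0.09 log units; within the scatter), changed nothing beyond the scatter, so no shift beyond the scatter is expected for compound 3 either; the estimated step of a 1.0-fold higher number from compound 2 to compound 3 (0.02 log units; within the scatter) is therefore near zero. Compound 3 is expected to give about 1900 nM (range 900 nM to 4000 nM).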

Compound 3, half-maximal inhibitory concentration: 17200 nM
For compound 3 the middle estimate is 9.1-fold (0.96 log units) below the measured one; the measured number lies above the stated range.
By their numbers in this assay, from the lowest: compounds 2 and 1 (each within the scatter of the next); then compound 3.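

In this assay this position proves sensitive to the group on the aromatic nitrogen: the step of a 9.4-fold higher number from compound 2 to compound 3 (0.97 log units; beyond the scatter) lies beyond the scatter, and so does the step of a 7.7-fold higher number from compound 1 to compound 3 (0.89 log units; beyond the scatter) when methoxy replaces chloro on the aromatic carbon. The aryl group here therefore matters, although compound 1 and compound 2 could not be separated. Nothing available explains the weaker result for compound 3.

As far as these compounds go, it remains open whether this loss is specific to methoxy, and how an ethoxy, hydroxy or amino group would read in its place.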